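A few compounds are considered here, and "the series" means these few. Any claim that something is new, unique, unknown or untested is made for them only; others in the source may bear on it.

Working notes on the series around the shared core of compound 1 `O=C(CCc1cccc2c1B(O)OC2)Nc1ccc(F)cc1`. For the measured compounds named here, in a functional assay on MDA-MB-231 cells (Homo sapiens) for antiproliferative activity, read by MTT assay, with a stated time of 72 h (on this read-out lower numbers stand for stronger inhibition and higher numbers for weaker inhibition), compound 1 gives 440 nM, the second highest of the three numbers so far. Compound 3 `O=C(CCc1cccc2c1B(O)OC2)Nc1cccc(-c2ccccc2)c1` in this assay gives 220 nM, and that value lies within the scatter of compound 1, so the two are not told apart. Compound 2 `Cc1cc(C)c(NC(=O)CCc2cccc3c2B(O)OC3)c(C)c1` in this assay gives 71000 nM, far beyond the scatter from compound 1 and the weakest of the three by a wide margin.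

The next step keeps the core and the amide-linked chain and alters the terminal ring of compound 1: phenyl in place of fluoro on an aromatic carbon. The resulting compound 4 `O=C(CCc1cccc2c1B(O)OC2)Nc1ccc(-c2ccccc2)cc1` has not yet been run in this assay. Going by the values given here, no step between measured compounds matches this change, so the expectation rests on compound 3, whose value 220 nM shows that a phenyl on the terminal ring is at least tolerated. The expected step from compound 1 is a 1.7-fold lower number from compound 1 to compound 4 (0.23 log units; within the scatter), small and within the scatter, toward a somewhat lower number. For compound 4 the estimate in this assay is 260 nM, with a range from 80 nM to 850 nM.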

Compound 4, half-maximal inhibitory concentration: 8800 nM
Compound 4: middle estimate off by 34-fold (1.53 log units), on the low side; measured number outside the range, above it.
By their numbers in this assay, from the lowest: compounds 3 and 1 (each within the scatter of the next); then compound 4; then compound 2.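

In this assay, phenyl in place of fluoro on this aromatic carbon, para to a large group, gives a 20-fold higher number from compound 1 to compound 4 (1.30 log units; beyond the scatter), so this position of the terminal ring does not accept the larger group without a clear loss. Phenyl on the terminal ring is therefore not tolerated at every carbon: compound 3, which carries its phenyl at a different carbon of that ring, gives 220 nM, whereas compound 4 gives 8800 nM. The data at hand offer no evidence on what lies behind this loss.

From the compounds shown here alone, whether chloro, methyl or methoxy at this carbon stays close to compound 1 or moves toward compound 4 remains open. Also open, going by these compounds, is whether an amine or a carboxylic acid on the added phenyl would change the number of compound 4.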